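Replacing the Hydroxycyclohexyl Amide with an Ethyl Amide

The source may report more compounds than this note shows. Statements on the series, on what has been measured and on what is new or still open speak of the compounds shown alone.

Compound 2 `CNC(=O)c1cc(C(=O)N[C@H]2CC[C@H](O)CC2)n([C@@H](C)c2ccccc2)n1` shares its core with compound 1 `CNC(=O)c1cc(C(=O)N[C@H]2CC[C@H](O)CC2)n([C@@H](C)c2ccc(Cl)cc2)n1` and compound 3 `CC[C@@H](c1ccccc1)n1nc(C(=O)NC)cc1C(=O)N[C@H]1CC[C@H](O)CC1`. In a physicochemical assay for lipophilicity (a lower number here means a more polar compound, a higher number a more lipophilic compound), compound 2 gives 2.9, the lower of the two numbers reported for this series; in this assay compound 1 gives 3.7, and in this assay compound 3 gives "not determined" (no result reported), so no number stands for it. Among the compounds with values here, the single measured step, a number 0.80 log units lower from compound 1 to compound 2 (beyond the scatter), describes hydrogen in place of chloro on an aromatic carbon and does not touch the amide side of the molecule.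

Compound 4 `CCNC(=O)c1cc(C(=O)NC)nn1[C@@H](C)c1ccccc1` differs from compound 2 by ethyl in place of 4-hydroxycyclohexyl on an amide-type nitrogen. Within the data shown here, no measured step covers this exchange on the amide-type nitrogen, and the step from compound 1 to compound 2 concerns a different position, so it gives no guidance on size or direction. What can be said rests on the counted difference itself: the group that leaves has seven heavy atoms with one hydrogen-bond donor and one hydrogen-bond acceptor, while the entering ethyl has two heavy atoms and neither. The author expects a modest move downward rather than none, and estimates that compound 4 gives 2.2 in this assay, between 1.6 and 2.8, an expected step of a number 0.70 log units lower from compound 2 to compound 4 (beyond the scatter).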

Compound 4, distribution coefficient: 3.7
The estimate for compound 4 lay 1.50 log units below the measured number; measured number above the stated range.
By their numbers in this assay, from the lowest: compound 2; then compounds 1 and 4 (each within the scatter of the next).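

Within the data shown here, on the amide-type nitrogen, the exchange of 4-hydroxycyclohexyl for ethyl gives in this assay a number 0.80 log units higher from compound 2 to compound 4 (beyond the scatter), the first measured step at this position. The earlier compounds had shown a change only on the aromatic ring, so this result establishes that the amide side also moves the number, and by a step beyond the scatter. The direction is also new: ethyl has fewer heavy atoms than 4-hydroxycyclohexyl, no ring and no hydrogen-bond donor or acceptor, yet the number rises, and nothing available here explains which of these differences accounts for the step.

The compounds shown cannot separate the loss of the ring from the loss of the hydroxyl group, which a plain cyclohexyl on the same nitrogen would address. Going by these compounds, it also remains open how a longer chain such as butyl, an amine or a carboxylic acid at this position would compare with ethyl, and whether the step would be the same with the chloro group on the aromatic ring.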